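This account rests on a few compounds, and the source may have more. Where it says the series, first, only, none or still open, it means among the compounds named here.

Measured in a functional assay on U-251 cells (Homo sapiens) for cytotoxicity; a lower number here means a stronger inhibitor of growth, a higher number a weaker inhibitor of growth:
- compound 1 `COc1ccc(C2=C(c3ccc(SC)cc3)CC3CCCN3C2=O)cc1Br`: 800 nM
- compound 2 `CSc1ccc(C2=C(c3ccc(Br)cc3)C(=O)N3CCCC3C2)cc1`: 7000 nM
- compound 3 `CSc1ccc(C2=C(c3ccc(C)cc3)C(=O)N3CCCC3C2)cc1`: 400 nM

Compound 3 sits level with compound 1 on these numbers, a 2.0-fold lower number from compound 1 to compound 3 (0.30 log units; within the scatter). Only compound 2 stands clearly apart from compound 3.

Next is compound 4 `CSc1ccc(C2=C(c3ccc(SC)cc3)C(=O)N3CCCC3C2)cc1`, with methylsulfanyl in place of methyl on an aromatic carbon. The 4-methylphenyl group thus becomes 4-(methylsulfanyl)phenyl, on a six-membered aromatic ring of carbon only, para to a large group.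

The closest evidence is the change at this same place, an 18-fold lower number from compound 2 to compound 3 (1.24 log units; beyond the scatter). Exchanging the whole group there also gave an 8.8-fold higher number from compound 1 to compound 2 (0.94 log units; beyond the scatter). The number therefore responds strongly to some replacements at this place and hardly at all to others. Within the data shown here, no measured compound carries methylsulfanyl there, so the direction remains uncertain. With compound 3 at 400 nM, and with the only clear departure from that level being upward, a modest rise is the more likely outcome, though no change beyond the scatter remains possible.

The step expected in this assay is a 1.8-fold higher number from compound 3 to compound 4 (0.24 log units; within the scatter).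

Compound 4 is estimated at 700 nM, with an expected range from 150 nM to 3000 nM.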

Compound 4, concentration for 50% growth inhibition: 5000 nM
Beside the measured number, compound 4's estimate is 7.1-fold (0.85 log units) below it, outside the stated range (above it).
By their numbers in this assay, from the lowest: compounds 3 and 1 (each within the scatter of the next); then compounds 4 and 2 (each within the scatter of the next).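

Working notes on this position, read in this assay: among the para substituents on this aromatic ring, methyl now looks like the exception rather than the baseline, as a 13-fold higher number from compound 3 to compound 4 (1.10 log units; beyond the scatter) shows that a substituent other than bromo can also lose the level held by compound 3. Methylsulfanyl and bromo read as level here, with a 1.4-fold lower number from compound 2 to compound 4 (0.15 log units; within the scatter) and so the high number at this place is not tied to bromo alone, and a single added sulfur atom on the methyl is enough to reach it. The whole-group exchange gives the same picture, since a 6.3-fold higher number from compound 1 to compound 4 (0.80 log units; beyond the scatter) places the 3-bromo-4-methoxyphenyl group clearly apart from 4-(methylsulfanyl)phenyl, as it already stood from 4-bromophenyl, while it stays level with 4-methylphenyl.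

As far as these compounds go, whether an ethyl, a methoxy, a hydroxyl or an amine at this place would read with methyl, or with bromo and methylsulfanyl, stays open, and three groups cannot settle a trend. Nothing at hand bears on what separates methyl from the other two groups.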